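The compounds below may be only part of what the source reports. "The series", "measured", "known", "first", "only" and "open" are said of these compounds alone.

Measured in an ADME assay (liver, Mus musculus) for metabolic stability, using microsomes; a lower number here means that the compound disappears faster, a higher number that the compound lasts longer:
- Compound 1 `CCc1nc2ccc(Cl)cn2c1C(=O)NCc1ccc(-c2ccc(C)cc2)cc1`: 0.677 h
- Compound 2 `CCc1nc2cc(Cl)ccn2c1C(=O)NCc1ccc(-c2ccc(C)cc2)cc1`: 0.385 h
- Compound 3 `CCc1nc2cc(Cl)ccn2c1C(=O)NCc1ccc(-c2ccc(C(=O)O)cc2)cc1`: > 2 h, a limit of the assay and not a number

In this assay, compound 2 gives 0.385 h, within the usual scatter of compound 1 at 0.677 h.

Compound 4 `CCc1nc2cc(Cl)ccn2c1C(=O)NCc1ccc(N2CCCCCC2)cc1` carries azepan-1-yl in place of 4-methylphenyl on an aromatic carbon.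

Going by the values given here, the one measured step that bears on this, an at least 5.1-fold higher number from compound 2 to compound 3 (0.71 log units; beyond the scatter), put carboxy in place of methyl on the same 4-methylphenyl group and went beyond the scatter. Among the compounds with values here, it shows that this end of the molecule can matter, but no measured step brings in azepan-1-yl, so its size does not carry over.

Only a small move, within the scatter, is expected: a 1.3-fold lower number from compound 2 to compound 4 (0.11 log units; within the scatter).

For compound 4 the estimate is 0.3 h, with an expected range of 0.1 h to 0.8 h.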

Compound 4, half-life: 0.0317 h
The estimate for compound 4 lay 9.5-fold (0.98 log units) above the measured number; measured number below the stated range.
By their numbers in this assay, from the lowest: compound 4; then compounds 2 and 1 (each within the scatter of the next). At a limit, above all of these: compound 3.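

Azepan-1-yl in place of 4-methylphenyl gives a 12-fold lower number from compound 2 to compound 4 (1.08 log units; beyond the scatter) in this assay, so changes at this position can shorten the half-life as well as lengthen it. Set against the carboxy-bearing compound, the same group gives an at least 63-fold lower number from compound 3 to compound 4 (1.79 log units; beyond the scatter). Compound 3 stands at a limit of the assay and not at a number: the limit of > 2 h in this assay, at which 1 of the 4 values shown sits.

As far as these compounds go, whether the drop follows the ring nitrogen, the seven-membered ring or the loss of the aromatic ring stays open. A piperidine ring or an open-chain amine at this place could begin to separate these.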